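Cyclopentyl Ester in Place of Thioester on a Shared Core

A few compounds are considered here, and "the series" means these few. Any claim that something is new, unique, unknown or untested is made for them only; others in the source may bear on it.

Measured so far, in an assay on membranes from HeLa cells for displacement of a labelled ligand from adenosine receptor A3 (Homo sapiens), read by scintillation counting, with a stated time of 180 min, tested at 1 uM; on this read-out lower numbers stand for less inhibition and higher numbers for more inhibition at the one concentration tested (going by the name of the read-out):
Compound 1 `CC1=C(C(=O)OC(C)(C)C)C(c2ccoc2)NC(=O)N1`: 2%
Compound 2 `CC(=O)C1=C(C)NC(=O)NC1c1ccoc1`: 2%
Compound 3 `CCSC(=O)C1=C(C)NC(=O)NC1c1ccoc1`: 1%

The three compounds share one core and differ only in the group on the carbonyl carbon. Compound 1 carries a tert-butoxy group there, compound 2 a methyl, and compound 3 an ethylsulfanyl. In this assay compound 3 gives 1%, the smallest of the three numbers, but the gaps to its neighbours are a number 1 percentage points lower from compound 1 to compound 3 (within the scatter) and a number 1 percentage points lower from compound 2 to compound 3 (within the scatter), both within the scatter, so nothing separates the three. The step of no change at the digits printed from compound 1 to compound 2 (within the scatter) tells the same: swapping the group on the carbonyl carbon has so far left the read-out untouched.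

Compound 4 `CC1=C(C(=O)OC2CCCC2)C(c2ccoc2)NC(=O)N1` is not yet measured. It differs from compound 3 as follows: cyclopentyloxy in place of ethylsulfanyl on a carbonyl carbon. All three measured steps bear on this change, since each of them also exchanges the group on the carbonyl carbon, and each was within the scatter. Compound 4 is therefore expected to stay where the others are, with a step of a number 1 percentage points higher from compound 3 to compound 4 (within the scatter) that does not exceed the scatter. In this assay compound 4 is estimated at 2%, with a range from -6% to 10%.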

Compound 4, a percentage reported as inhibition, at one concentration (the size of the read-out at that concentration, not a potency): 1%
The estimate for compound 4 lay 1 percentage points above the measured number, within the range that was stated.
By their numbers in this assay, from the lowest: compounds 3, 4, 1 and 2 (each within the scatter of the next).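

In this assay, within the data shown here, cyclopentyloxy is the only group on this carbonyl carbon that brings a ring of its own, one five-membered non-aromatic ring of carbon only, and it has 6 heavy atoms where ethylsulfanyl has 3, yet the exchange gives no change at the digits printed from compound 3 to compound 4 (within the scatter). The comparisons with the other two groups read the same way, with a number 1 percentage points lower from compound 2 to compound 4 (within the scatter) against methyl and a number 1 percentage points lower from compound 1 to compound 4 (within the scatter) for cyclopentyl in place of tert-butyl, so a ring in this group, like the earlier changes without one, has not separated any of the compounds at this place. Nothing at hand speaks to what lies behind this flat read-out.

As far as these compounds go, whether a carboxylic acid, a group carrying an amine or a longer alkoxy chain on this carbonyl carbon would shift the read-out beyond the scatter remains open. Also open, from the compounds shown here alone, is whether changing the shared core elsewhere, rather than this group, would move the number, and how these compounds would read at any concentration other than the single one tested.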